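The source may report more compounds than this note shows. Statements on the series, on what has been measured and on what is new or still open speak of the compounds shown alone.

The measured compounds are compound 1 `COc1ccc2[nH]c(-c3ccccc3F)cc(=O)c2c1OC`, compound 2 `COc1ccc2[nH]c(-c3cccc(F)c3)cc(=O)c2c1OC` and compound 3 `COc1cc2c(=O)cc(-c3ccccc3F)[nH]c2cc1O`. Compound 1 gives only a limit in a functional assay on HCT-116 cells (Homo sapiens) for cytotoxicity, read by MTT assay, with a stated time of 48 h (on this read-out lower numbers stand for stronger inhibition and higher numbers for weaker inhibition), namely > 20000 nM; that is the limit of > 20000 nM in this assay, at which 1 of the 3 values shown sits. Compound 2 gives 1200 nM and compound 3 gives 5800 nM in this assay.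

The change 3-fluorophenyl in place of 2-fluorophenyl on an aromatic carbon produced an at least 16-fold lower number from compound 1 to compound 2 (1.22 log units; beyond the scatter). How the core of compound 3 differs from the core of compound 1 is not broken down here.

Compound 4 `COc1cc2c(=O)cc(-c3cccc(F)c3)[nH]c2cc1O` has not yet been measured. It carries the same change as before, (3-fluorophenyl in place of 2-fluorophenyl on an aromatic carbon), made on the core of compound 3. The step is expected to be a 15-fold lower number from compound 3 to compound 4 (1.16 log units; beyond the scatter), resting on the step from compound 1 to compound 2, which was at least large since compound 1 sits at a limit. Compound 4 is therefore estimated at 400 nM, between 120 nM and 1500 nM.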

Compound 4, half-maximal inhibitory concentration: 1100 nM
Compound 4: the middle estimate sits 2.8-fold (0.44 log units) below what was measured, and the stated range covers the measured number.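

Carried to a second core, 3-fluorophenyl in place of 2-fluorophenyl again gives a lower number in this assay, with a 5.3-fold lower number from compound 3 to compound 4 (0.72 log units; beyond the scatter). The direction of the change therefore holds on both cores shown, but its size does not carry over unchanged: the same change on two cores in this assay, an at least 16-fold lower number (1.22 log units; beyond the scatter) from compound 1 to compound 2 and a 5.3-fold lower number (0.72 log units; beyond the scatter) from compound 3 to compound 4, at least 3.1-fold (0.49 log units) apart, beyond the scatter of two such steps. Compound 1 gives only a limit, so the first step has no exact size and the gap between the two steps is known only as a minimum: the limit of > 20000 nM in this assay, at which 1 of the 4 values shown sits.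

The compounds shown cover only two cores and only these two fluorophenyl groups. Going by these compounds, whether the same trend would hold for a chlorophenyl or methoxyphenyl group, or on a core carrying an amine, remains open.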